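Oxan-4-yl in place of hydroxyalkyl on the ring nitrogen

The compounds below may be only part of what the source reports. "The series", "measured", "known", "first", "only" and "open" are said of these compounds alone.

Measured in an assay on BaF3 cells for inhibition of proto-oncogene tyrosine-protein kinase receptor Ret (Homo sapiens), read by MTT assay, with a stated time of 48 h; on this read-out lower numbers stand for stronger inhibition of growth and higher numbers for weaker inhibition of growth:
compound 1 `CC(C)(O)Cn1nc(-c2cc(C3CC3)on2)c2c(N)ncnc21`: 1770 nM
compound 2 `CC(C)n1nc(/C=N/OCc2ccccc2)c2c(N)ncnc21`: 7410 nM
compound 3 `CC(C)n1nc(/C=N/O)c2c(N)ncnc21`: a limit only, > 10000 nM

Compound 1 holds the lowest of the two numbers; compound 2 lies beyond the scatter above it. Compound 3 sits at the limit of > 10000 nM in this assay, at which 1 of the 3 values shown sits. Among the measured compounds shown here, the one measured step, an at least 1.3-fold higher number from compound 2 to compound 3 (0.13 log units; that floor lies within the scatter), concerns the oxygen of the oxime and not the ring nitrogen, and its floor lies within the scatter. Compound 4 `Nc1ncnc2c1c(-c1cc(C3CC3)on1)nn2C1CCOCC1` differs from compound 1 by oxan-4-yl in place of 2-hydroxy-2-methylpropyl on an aromatic nitrogen. For the measured compounds named here, no measured step touches this ring nitrogen, so no direction beyond the scatter is expected for a 1.0-fold lower number from compound 1 to compound 4 (0.02 log units; within the scatter). Compound 4 is therefore estimated at 1700 nM, between 450 nM and 6500 nM.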

Compound 4, concentration for 50% growth inhibition: 440 nM
Beside the measured number, compound 4's estimate is 3.9-fold (0.59 log units) above it; the whole stated range lies above it.
By their numbers in this assay, from the lowest: compound 4; then compound 1; then compound 2. At a limit, above all of these: compound 3.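

Among the compounds shown here, the ring nitrogen responds to its substituent: oxan-4-yl in place of 2-hydroxy-2-methylpropyl gives a 4.0-fold lower number from compound 1 to compound 4 (0.60 log units; beyond the scatter), the first step at this position and one that leaves the rest of the structure unchanged. The change replaces an open chain bearing a hydrogen-bond donor with a six-membered non-aromatic ring bearing none. Nothing measured here bears on why the number falls.

Going by these compounds, whether the ring or the missing hydroxyl matters remains open. Cyclohexyl or 2-methoxyethyl on this nitrogen would separate the two, and a piperidin-4-yl amine would test a ring nitrogen in place of the oxygen.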